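The source may report more compounds than this note shows. Statements on the series, on what has been measured and on what is new or still open speak of the compounds shown alone.

Compound 1 `COc1cc(-c2nn(-c3cccc(NC(=O)Nc4cccc(C(F)(F)F)c4)c3)cc2-c2ccncc2)ccc1Cl` — in a functional assay on NCI-H23 cells (Homo sapiens) for inhibition, read by sulforhodamine B assay, with a stated time of 48 h (on this read-out lower numbers stand for stronger inhibition of growth and higher numbers for weaker inhibition of growth), compound 1 gives 3410 nM.
Compound 2 `COc1cc(-c2nn(-c3cccc(NC(=O)Nc4ccc(Cl)c(C(F)(F)F)c4)c3)cc2-c2ccncc2)ccc1Cl` — in this assay compound 2 gives 8030 nM.

For the measured compounds named here, compound 2 has the highest of the two numbers so far; its nearest neighbour is compound 1, and the step of a 2.4-fold higher number from compound 1 to compound 2 (0.37 log units; beyond the scatter) places compound 2 beyond the scatter on the weaker side. Compound 3 `COc1cc(-c2nn(-c3cccc(NC(=O)c4ccccc4)c3)cc2-c2ccncc2)ccc1Cl` has not been measured. It differs from compound 2 in one place: phenyl in place of (4-chloro-3-(trifluoromethyl)phenyl)amino on a carbonyl carbon. Going by the values given here, no measured step matches this change; the only step available, from compound 1 to compound 2, concerns a chloro on the same aryl group and was modest. Since the whole arylamino portion that carried that chloro is gone, its direction gives limited guidance, and compound 3 is expected to move further toward weaker inhibition, with a step of a 2.2-fold higher number from compound 2 to compound 3 (0.35 log units; beyond the scatter) that is uncertain. Compound 3 is estimated at 18000 nM, within 5000 nM to 60000 nM.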

Compound 3, concentration for total growth inhibition: > 100000 nM
Compound 3: no number, only a limit; the forecaster's own chance of this, stated with the estimate: 25%; middle value at least 5.5-fold (0.74 log units) away from the limit.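

In this assay compound 3 gives no number, only a limit: the limit of > 100000 nM in this assay, at which 1 of the 3 values shown sits.

The earlier compounds shown here showed only a modest shift on adding a chloro to the aryl group, whereas removing the arylamino group altogether has a large effect. Phenyl in place of (4-chloro-3-(trifluoromethyl)phenyl)amino on the carbonyl carbon gives an at least 12-fold higher number from compound 2 to compound 3 (1.09 log units; beyond the scatter), and phenyl in place of (3-(trifluoromethyl)phenyl)amino gives an at least 29-fold higher number from compound 1 to compound 3 (1.46 log units; beyond the scatter). So the two compounds that keep an arylamino group on this carbonyl carbon give numbers, and the one with phenyl there does not.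

The change removes the amino nitrogen, with its hydrogen, and the trifluoromethyl group at once, so the compounds shown cannot say which of these loss matters. A plain phenylamino group on the same carbonyl carbon, or a trifluoromethyl on the entering phenyl, would separate the two.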